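Permeability notes: acetylpiperidine in place of pyrrolylphenyl

This account rests on a few compounds, and the source may have more. Where it says the series, first, only, none or still open, it means among the compounds named here.

Going by the values given here, compound 1 `Cn1cncc1CN1CC(N(Cc2cccc(-n3cccc3)c2)S(=O)(=O)c2ccccn2)Cc2cc(C#N)ccc21` gives 2.3 10^-6 cm/s in an ADME assay on Caco-2 cells (Homo sapiens) for permeability, in the apical to basolateral direction (on this read-out lower numbers stand for lower permeability and higher numbers for higher permeability), the highest of the three numbers measured so far. Compound 2 `Cn1cncc1CN1CC(N(CC2CCN(C(=O)N3CCCC3)CC2)S(=O)(=O)c2ccccn2)Cc2cc(C#N)ccc21` gives 0.6 10^-6 cm/s and compound 3 `Cn1cncc1CN1CC(N(CC2CCN(C(=O)c3ccco3)CC2)S(=O)(=O)c2ccccn2)Cc2cc(C#N)ccc21` gives 0.5 10^-6 cm/s, both well below compound 1 in this assay. Among the compounds with values here, the one directly comparable step, a 1.2-fold lower number from compound 2 to compound 3 (0.08 log units; within the scatter), shows that exchanging the group on the carbonyl carbon of the piperidine-bearing chain changes little.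

Compound 4 `CC(=O)N1CCC(CN(C2Cc3cc(C#N)ccc3N(Cc3cncn3C)C2)S(=O)(=O)c2ccccn2)CC1` differs from compound 1 by 1-acetylpiperidin-4-yl in place of 3-(1H-pyrrol-1-yl)phenyl on a saturated chain carbon bound to a sulfonamide nitrogen. Like compounds 2 and 3, compound 4 carries a carbonyl on a piperidine ring in this position. A drop beyond the scatter is therefore expected for compound 4, because compound 2 gives 0.6 10^-6 cm/s and compound 3 gives 0.5 10^-6 cm/s. The step from compound 1 is estimated at a 3.8-fold lower number from compound 1 to compound 4 (0.58 log units; beyond the scatter). Compound 4 is expected at 0.6 10^-6 cm/s, in the range 0.3 10^-6 cm/s to 1.3 10^-6 cm/s.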

Compound 4, apparent permeability: 0.5 10^-6 cm/s
Compound 4: middle estimate off by 1.2-fold (0.08 log units), on the high side; low and high end bracket the measured number.
By their numbers in this assay, from the lowest: compounds 3, 4 and 2 (each within the scatter of the next); then compound 1.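

In this assay the exchange on a saturated chain carbon bound to a sulfonamide nitrogen now has a direct reading: 1-acetylpiperidin-4-yl in place of 3-(1H-pyrrol-1-yl)phenyl gives a 4.6-fold lower number from compound 1 to compound 4 (0.66 log units; beyond the scatter) in a single-place step. With no change at the digits printed from compound 3 to compound 4 (within the scatter) and a 1.2-fold lower number from compound 2 to compound 4 (0.08 log units; within the scatter) in this assay the carbonyl substituents methyl, furan-2-yl and pyrrolidin-1-yl cannot be told apart. Nothing available explains the drop.

Open, from the compounds shown here alone, is whether a plain phenyl, or a piperidine with its ring amine free, on that chain carbon would read nearer compound 1 or compound 4.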